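Compound 4: hydroxyphenyl in place of methylphenyl on the core

This account rests on a few compounds, and the source may have more. Where it says the series, first, only, none or still open, it means among the compounds named here.

Compound 2 `Cc1ccc(-c2cn(C/C=C3\OC(=O)C(OCc4ccccc4)=C3OCc3ccccc3)nn2)cc1` carries a 4-methylphenyl on the five-membered ring of the shared core. In a functional assay on HCT-116 cells (Homo sapiens) for antiproliferative activity, read by MTT assay, with a stated time of 72 h (a lower number here means a stronger inhibitor, a higher number a weaker inhibitor), compound 2 gives only a limit, > 100000 nM. Compound 1 `O=C1O/C(=C\Cn2cc(-c3cc(F)cc(F)c3)nn2)C(OCc2ccccc2)=C1OCc1ccccc1` likewise gives only a limit in this assay, > 100000 nM. The step between these two, a step that the two limits leave unreadable from compound 1 to compound 2, therefore cannot be read. Both sit at the limit of > 100000 nM in this assay, at which 2 of the 3 values shown sit. Going by the values given here, compound 3 `O=C1O[C@H]([C@@H](O)Cn2cc(CNS(=O)(=O)c3ccc(F)cc3)nn2)C(OCc2ccccc2)=C1OCc1ccccc1` has a different core and gives 22900 nM in this assay; it shares no single-point step with compound 2, so its value shows only that a measurable number occurs in the wider set.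

Compound 4 `O=C1O/C(=C\Cn2cc(-c3cccc(O)c3)nn2)C(OCc2ccccc2)=C1OCc1ccccc1` is compound 2 with 3-hydroxyphenyl in place of 4-methylphenyl on an aromatic carbon. Among the compounds with values here, no step with a readable size bears on this change; the only step at the same position is unreadable. For compound 4 the expected step is a number no higher from compound 2 to compound 4 (the limit leaves the size open), no more than the scatter. Compound 4 is estimated at 100000 nM, within 30000 nM to 300000 nM, with a high chance that only a limit is reported.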

Compound 4, half-maximal inhibitory concentration: 63600 nM
Compound 4: middle estimate off by 1.6-fold (0.20 log units), on the high side; low and high end bracket the measured number.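

Among compound 1, compound 2 and compound 4, which share a core, only compound 4 gives a number rather than a limit in this assay, so a value can be read at this aromatic carbon of the shared core. Placing 3-hydroxyphenyl here in place of 4-methylphenyl gives an at least 1.5-fold lower number from compound 2 to compound 4 (0.19 log units; that floor lies within the scatter), and placing it here in place of 3,5-difluorophenyl gives an at least 1.5-fold lower number from compound 1 to compound 4 (0.19 log units; that floor lies within the scatter). Both steps are floors, and their full size stays open, as each starts from a limit: the limit of > 100000 nM in this assay, at which 2 of the 4 values shown sit.

On these data alone, what a 3-methoxyphenyl or a 3-aminophenyl would give on this carbon remains open. The compounds shown therefore do not separate the effect of the hydroxy group from that of its placement on the phenyl ring.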